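Chloro in place of hydrogen: compound 3 to compound 4

The source may hold more compounds than are shown below. What is called first, only, known or untested is meant among the compounds shown, and "the series" means these compounds.

In an ADME assay on RAW264.7 cells (Mus musculus) for cytotoxicity, read by MTT assay, with a stated time of 72 h, tested at 50 uM (on this read-out higher numbers stand for a stronger effect at the one concentration tested and lower numbers for a weaker effect), compound 3 `O=C(Cn1c(=O)oc2ccccc21)Nc1ccccn1` gives 20.2%, the lowest of the three numbers; compound 2 `O=C(Cn1c(=O)oc2cc(Cl)ccc21)NCc1cccs1` gives 20.3%, within the scatter of it, and compound 1 `O=C(Cn1c(=O)oc2cc([N+](=O)[O-])ccc21)Nc1ccccn1` gives 38.6%, beyond the scatter. Compound 4 `O=C(Cn1c(=O)oc2cc(Cl)ccc21)Nc1ccccn1` differs from compound 3 by chloro in place of hydrogen on an aromatic carbon. For the measured compounds named here, the one measured step that touches this position is a number 18.4 percentage points lower from compound 1 to compound 3 (beyond the scatter), a modest step in which nitro at this place goes with the higher number. Chloro is not nitro, and compound 2 carries chloro on a different amide, so its number speaks to compound 4 only loosely. A small rise, within or just beyond the scatter, is therefore expected: a number 7.8 percentage points higher from compound 3 to compound 4 (within the scatter). For compound 4 the estimate in this assay is 28%, with a range from 15% to 42%.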

Compound 4, a percentage reported as inhibition, at one concentration (the size of the read-out at that concentration, not a potency): 33%
The estimate for compound 4 lay 5 percentage points below the measured number; low and high end bracket the measured number.
By their numbers in this assay, from the lowest: compounds 3 and 2 (each within the scatter of the next); then compounds 4 and 1 (each within the scatter of the next).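

In this assay chloro on this aromatic carbon gives a number 12.8 percentage points higher from compound 3 to compound 4 (beyond the scatter), so the higher number at this place is not confined to nitro. Chloro in place of nitro gives a number 5.6 percentage points lower from compound 1 to compound 4 (within the scatter), so the two groups are not separated here. With chloro held, pyridin-2-yl in place of (thiophen-2-yl)methyl on the amide-type nitrogen gives a number 12.7 percentage points higher from compound 2 to compound 4 (beyond the scatter), making that nitrogen a second place that moves the number.

Nothing available explains either change. Going by these compounds, whether an amine or a methoxy group on this aromatic carbon would behave like chloro and nitro remains open.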